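The compounds below may be only part of what the source reports. "The series", "measured", "known", "first", "only" and "open" are said of these compounds alone.

Measured so far in an ADME assay on the whole organism with Oryza sativa as the target, tested at 1 uM; a lower number here means a stronger effect, a higher number a weaker effect of the compound at the concentration tested:
compound 1, `C[C@H](NC(=O)Nc1cccc(F)c1)c1ccccc1`, gives 94%;
compound 2, `C[C@@H](NC(=O)Nc1cc(F)cc(F)c1)c1ccccc1`, gives 98%.

Compound 2 holds the higher of the two numbers, but compound 1 sits only a few points lower, a gap that lies within the usual scatter of this assay, so the two read as alike. For the measured compounds named here, no step between two measured compounds that differ in one place is available, and nothing in these two numbers tells how a change of configuration alone plays out.

Compound 3, `C[C@H](NC(=O)Nc1cc(F)cc(F)c1)c1ccccc1`, is the next candidate for this assay. Compared with compound 2: the two compounds have the same atoms and bonds and differ only in configuration as drawn: 1 of 1 stereo elements differ; a stereocentre at a saturated chain carbon is drawn R in compound 2 and S in compound 3.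

Going by the values given here, with no measured precedent for such a change, the step expected from compound 2 to compound 3 is a number 4 percentage points lower from compound 2 to compound 3 (within the scatter), that is, none beyond the scatter, though a real difference between the two configurations cannot be ruled out. The estimate for compound 3 in this assay is 94%, expected to fall between 80% and 100%.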

Compound 3, a percentage reported as activity, at one concentration (the size of the read-out at that concentration, not a potency): 99%
For compound 3 the middle estimate is 5 percentage points below the measured one; the measured number falls inside the stated range.
By their numbers in this assay, from the lowest: compounds 1, 2 and 3 (each within the scatter of the next).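

In this assay, for the compounds shown here, changing the stereocentre at a saturated chain carbon from R to S gives a number 1 percentage points higher from compound 2 to compound 3 (within the scatter), the first direct reading of configuration alone, and it shows no separation at the concentration tested. Fluoro in place of hydrogen on an aromatic carbon, with the configuration as drawn held the same, gives a number 5 percentage points higher from compound 1 to compound 3 (within the scatter), so this change also shows nothing beyond the scatter. The reading of the stereocentre rests on a clean single-point comparison: the fact that compounds 2 and 3 differ only in the configuration as drawn.

The compounds shown leave open whether any change to the shared core can move this read-out beyond the scatter, since only fluoro and hydrogen appear on the aromatic carbons. An amine or a carboxylic acid in place of fluoro, or a longer chain at the stereocentre, would test this.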